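Ortho substituent on the biaryl: cyano to methoxy

The source may report more compounds than this note shows. Statements on the series, on what has been measured and on what is new or still open speak of the compounds shown alone.

Among the compounds with values here, compound 3 `N#Cc1ccccc1-c1cccc(CNc2ccc(OCC(=O)O)c(F)c2)c1` gives the highest number of the three measured so far in a functional assay on CHO cells for agonist activity at Free fatty acid receptor 1 (Homo sapiens), read by FLIPR and calcium flux (on this read-out lower numbers stand for an effect already at smaller amounts and higher numbers for an effect only at larger amounts of compound), at 729 nM. Compound 1 `Cc1ccccc1-c1cccc(CNc2ccc(OCC(=O)O)c(F)c2)c1` gives 4.8 nM in this assay, and compound 2 `CC(C)c1ccccc1-c1cccc(CNc2ccc(OCC(=O)O)c(F)c2)c1` gives 86.2 nM. The steps are an 18-fold higher number from compound 1 to compound 2 (1.25 log units; beyond the scatter) and a 150-fold higher number from compound 1 to compound 3 (2.18 log units; beyond the scatter), with an 8.5-fold higher number from compound 2 to compound 3 (0.93 log units; beyond the scatter) between the two larger groups. Compound 4 `COc1ccccc1-c1cccc(CNc2ccc(OCC(=O)O)c(F)c2)c1` carries the change (methoxy in place of cyano on an aromatic carbon), on an aromatic carbon of a six-membered aromatic ring of carbon only, ortho to a large group. Within the data shown here, no measured step has a methoxy group, so the bearing of the existing steps is indirect: the cyano group sits at the top of the range, and the small methyl group of compound 1 at the bottom, with the larger isopropyl group of compound 2 in between. A methoxy group of the same heavy-atom count as the cyano it replaces is expected to move the number down substantially, toward compound 1 but short of it. The estimate for compound 4 in this assay is 20 nM, with a range from 5 nM to 100 nM, meaning an expected step of a 36-fold lower number from compound 3 to compound 4 (1.56 log units; beyond the scatter).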

Compound 4, half-maximal effective concentration in the Free fatty acid receptor 1 assay: 536 nM
For compound 4 the middle estimate is 27-fold (1.43 log units) below the measured one, and the stated range ends below it.
By their numbers in the Free fatty acid receptor 1 assay, from the lowest: compound 1; then compound 2; then compounds 4 and 3 (each within the scatter of the next).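

In the Free fatty acid receptor 1 assay compound 4 gives 536 nM, and the step is a 1.4-fold lower number from compound 3 to compound 4 (0.13 log units; within the scatter), so cyano and methoxy on this aromatic carbon cannot be told apart, although one carries a triple bond and the other does not. Methyl remains clearly separate, with a 110-fold higher number from compound 1 to compound 4 (2.05 log units; beyond the scatter), and isopropyl also stands apart from methoxy, with a 6.2-fold higher number from compound 2 to compound 4 (0.79 log units; beyond the scatter); among these four compounds, matching cyano and methoxy therefore places both at the high end, while the step from methyl is large whichever of the two enters. No supporting information is available to explain these differences. In a physicochemical assay for lipophilicity, read by HPLC, in phosphate buffer, measured as octanol-water partition, at pH 7.4, tested at 100 uM (on this read-out lower numbers stand for lower lipophilicity and higher numbers for higher lipophilicity), compound 3 is recorded as "not determined" (no result reported) and compound 4 as "not determined" (no result reported), so no comparison between them can be read there.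

The compounds shown leave open whether any other group on this carbon, such as ethyl, chlorine or an amine, comes close to compound 1. They also leave open whether the order of methyl, isopropyl, methoxy and cyano holds on a different core.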